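A few compounds are considered here, and "the series" means these few. Any claim that something is new, unique, unknown or untested is made for them only; others in the source may bear on it.

In a functional assay on the whole organism with Canis familiaris (Canis lupus familiaris) as the target (a lower number here means that less compound is needed, a higher number that more compound is needed for the effect), compound 3 `COc1cc(SC)ccc1-c1nc2cc[nH]cc-2n1` gives 0.2 mg/kg. That places it level, within the scatter, with compound 2 `COc1cc(C)ccc1-c1nc2cc[nH]cc-2n1` at 0.28 mg/kg, and well clear of compound 1 `CSc1ccc(-c2nc3cc[nH]cc-3n2)cc1` at 4 mg/kg.

The next structure, compound 4 `COc1cc(OS(C)(=O)=O)ccc1-c1nc2cc[nH]cc-2n1`, keeps the methoxy group and the shared core, but carries (methylsulfonyl)oxy in place of methylsulfanyl on an aromatic carbon, meta to that methoxy group: (methylsulfonyl)oxy in place of methylsulfanyl on an aromatic carbon.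

Going by the values given here, two measured steps bear on this change. Methoxy in place of hydrogen gave a 20-fold lower number from compound 1 to compound 3 (1.30 log units; beyond the scatter), a large step, and compound 4 retains that methoxy group. Methylsulfanyl in place of methyl, at the very position that now changes, gave only a 1.4-fold lower number from compound 2 to compound 3 (0.15 log units; within the scatter). Among the compounds with values here, that hints that this position tolerates a swap, although the entering group is larger than either group compared there, and no measured compound carries it. A modest move towards a higher number is therefore expected, with an estimated 2.0-fold higher number from compound 3 to compound 4 (0.30 log units; within the scatter). For compound 4 the estimated value is 0.4 mg/kg, with an expected range from 0.1 mg/kg to 1.5 mg/kg.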

Compound 4, dose for half-maximal effect: 0.006 mg/kg
Beside the measured number, compound 4's estimate is 67-fold (1.82 log units) above it; measured number outside the range, below it.
By their numbers in this assay, from the lowest: compound 4; then compounds 3 and 2 (each within the scatter of the next); then compound 1.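

Compounds 2 and 3 suggested that this position hardly mattered, but the swap to (methylsulfonyl)oxy shows that it can matter a great deal in this assay (a 33-fold lower number from compound 3 to compound 4 (1.52 log units; beyond the scatter); a 47-fold lower number from compound 2 to compound 4 (1.67 log units; beyond the scatter)). The ring carbon meta to the methoxy group therefore does more than tolerate a change, and replacing either smaller group with this one has a large effect on the dose needed. The entering group differs from methylsulfanyl in several ways at once, with 5 heavy atoms against 2 and 3 hydrogen-bond acceptors against 1, and nothing available here separates these differences or explains the gain.

As far as these compounds go, it remains open whether a methylsulfonyl group joined directly to the ring, without the linking oxygen, would give a similar result. The effect of a longer chain on the sulfur, or of an amine at this position, is also unknown, as is whether the gain depends on the methoxy group.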